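Swapping methyl for chloro on a triazole-linked sulfonamide

The source may hold more compounds than are shown below. What is called first, only, known or untested is meant among the compounds shown, and "the series" means these compounds.

Measured so far:
- Compound 1, `O=c1[nH]cc(S(=O)(=O)Nc2ccccc2-c2cn(-c3ccccc3Cl)nn2)c(=O)[nH]1`: 22800 nM
- Compound 2, `Cc1cccc(-n2cc(-c3cccc(NS(=O)(=O)c4c[nH]c(=O)[nH]c4=O)c3)nn2)c1`: 28300 nM
- Compound 3, `Cc1ccc(-n2cc(-c3ccc(NS(=O)(=O)c4c[nH]c(=O)[nH]c4=O)cc3)nn2)cc1`: "not toxic" (no number reported)

Three compounds share a sulfonamide-linked core carrying a triazole and a substituted phenyl ring. In an ADME assay on L02 cells (Homo sapiens) for cytotoxicity, read by MTT assay, with a stated time of 24 h (a lower number here means that less compound is tolerated, a higher number that more compound is tolerated), compound 1 gives 22800 nM and compound 2 gives 28300 nM; these two values lie within the usual scatter of each other, so nothing separates them. Compound 3 is reported only as "not toxic" (no number reported) in this assay, with no single number attached, so its exact standing cannot be placed on the same scale as compounds 1 and 2. All three are tolerated by the liver cells up to fairly high concentrations.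

Compound 4, `O=c1[nH]cc(S(=O)(=O)Nc2ccc(-c3cn(-c4ccc(Cl)cc4)nn3)cc2)c(=O)[nH]1`, has not been measured. It differs from compound 3 by one change: chloro in place of methyl on an aromatic carbon. For the measured compounds named here, no step between measured compounds carries this change, so its effect on this assay is unknown. Given that compound 3 shows no toxicity and that compounds 1 and 2 sit at high concentrations, compound 4 is expected to remain well tolerated, with no step beyond the scatter anticipated. Compound 4 is estimated at 30000 nM, in a range from 12000 nM to 90000 nM, with a real chance that only a limit is reported.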

Compound 4, half-maximal cytotoxic concentration: 42900 nM
Estimate against measurement, compound 4: 1.4-fold (0.16 log units) below, and the stated range covers the measured number.
By their numbers in this assay, from the lowest: compounds 1, 2 and 4 (each within the scatter of the next).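

For the compounds shown here, with no number for compound 3, no step to compound 4 can be read: in this assay compound 3 stands as "not toxic" (no number reported) and compound 4 gives 42900 nM in the same test. No measurement shown here offers an explanation for this result. The compounds shown leave open how changing 4-methylphenyl to 4-chlorophenyl affects tolerance in these cells.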